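Ester to Hydroxyalkyl Amide: Expected Shift in Cell Growth Inhibition

The source may hold more compounds than are shown below. What is called first, only, known or untested is meant among the compounds shown, and "the series" means these compounds.

Compound 1 `C=CCN(C)C(=O)c1ccc(C(CC)(CC)c2ccc(OCCC(O)(CC)CC)c(C)c2)n1CC` gives 1190 nM in an ADME assay on L02 cells (Homo sapiens) for antiproliferative activity, read by MTT assay, with a stated time of 48 h; a lower number here means a stronger inhibitor, a higher number a weaker inhibitor.
Compound 2 `C#CCCOC(=O)c1ccc(C(CC)(CC)c2ccc(OCCC(O)(CC)CC)c(C)c2)n1CC` gives only the assay limit > 50000 nM.
Compound 3 `CCn1c(C(=O)NC(CO)CCO)ccc1C(CC)(CC)c1ccc(OCCC(O)(CC)CC)c(C)c1` gives 3040 nM in this assay.

Among the compounds with values here, compound 2 stands apart from the other two: its value is a limit of the assay, not a measured number, and it is the one value that sits at the limit of > 50000 nM in this assay, at which 1 of the 3 values shown sits. So its true number is known only to lie beyond that point.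

Compound 4 `CCn1c(C(=O)NC(C)CO)ccc1C(CC)(CC)c1ccc(OCCC(O)(CC)CC)c(C)c1` differs from compound 2 by one change on the carbonyl carbon: (1-(hydroxymethyl)ethyl)amino in place of (but-3-yn-1-yl)oxy on a carbonyl carbon

Within the data shown here, two measured steps bear on this change. The first is an at least 16-fold lower number from compound 2 to compound 3 (1.21 log units; beyond the scatter), which swaps the same (but-3-yn-1-yl)oxy group for a nitrogen-linked group carrying hydroxyl, and it lifts the compound off the limit by a large margin. The second is a 2.6-fold higher number from compound 1 to compound 3 (0.41 log units; beyond the scatter), which shows that such a hydroxyl-bearing nitrogen-linked group gives a modestly higher number than the allyl(methyl)amino group of compound 1.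

A large step downward is therefore expected: an at least 16-fold lower number from compound 2 to compound 4 (1.22 log units; beyond the scatter). Compound 4 is expected to give 3000 nM in this assay, within 1000 nM to 10000 nM.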

Compound 4, half-maximal inhibitory concentration: 4840 nM
Estimate against measurement, compound 4: 1.6-fold (0.21 log units) below; low and high end bracket the measured number.
By their numbers in this assay, from the lowest: compound 1; then compounds 3 and 4 (each within the scatter of the next). At a limit, above all of these: compound 2.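

In this assay, the step of an at least 10-fold lower number from compound 2 to compound 4 (1.01 log units; beyond the scatter) shows that the large drop from the ester is not tied to the group of compound 3, since (1-(hydroxymethyl)ethyl)amino on the same carbonyl carbon also brings the number far down. From the compounds shown here alone, the true size of that step stays unknown, as compound 2 gives a limit and not a number: the limit of > 50000 nM in this assay, at which 1 of the 4 values shown sits. The step of a 1.6-fold higher number from compound 3 to compound 4 (0.20 log units; within the scatter) lies within the scatter, so the two hydroxyl-bearing amides cannot be told apart and the extra hydroxymethyl shows no readable effect, while a 4.1-fold higher number from compound 1 to compound 4 (0.61 log units; beyond the scatter) lies beyond it and leaves the allyl(methyl)amino group with the lowest number of the four.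

Only one ester is shown, so it remains open whether a plain methyl ester or a carboxylic acid on this carbonyl carbon would also sit far from the amides. Going by these compounds, it is also open whether an amine or a longer chain in place of the hydroxyl-bearing side chain would reach the number of compound 1 or pass it.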